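Extending methyl to propyl: compound 3 to compound 4

A few compounds are considered here, and "the series" means these few. Any claim that something is new, unique, unknown or untested is made for them only; others in the source may bear on it.

Compound 1 `Cc1[nH]c(=O)n(C)c1-c1ccccc1`: > 100000 nM (a limit)
Compound 2 `CCCCc1ccc(-c2c(C)[nH]c(=O)n2C)cc1`: 10700 nM
Compound 3 `Cc1ccc(-c2c(C)[nH]c(=O)n2C)cc1`: 85300 nM

All values are half-maximal inhibitory concentrations in a functional assay on brain (Rattus norvegicus, strain Wistar) for inhibition; a higher number here means a weaker inhibitor, a lower number a stronger inhibitor (the read-out throughout). The value of compound 1 is a limit of the assay, not a number. Compound 3 holds the higher of the two true numbers. The gap to the other is an 8.0-fold higher number from compound 2 to compound 3 (0.90 log units; beyond the scatter) and is the main guide here. The step of an at least 1.1-fold lower number from compound 1 to compound 3 (0.06 log units; that floor lies within the scatter) has a floor within the scatter and fixes little, whereas an at least 9.3-fold lower number from compound 1 to compound 2 (0.97 log units; beyond the scatter) goes beyond it.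

The change to compound 4 `CCCc1ccc(-c2c(C)[nH]c(=O)n2C)cc1` is ethyl in place of hydrogen on a saturated chain carbon bound to an aromatic carbon and, cut one bond further out, reads methyl to propyl. Propyl falls short of the butyl of compound 2 at 10700 nM (the nearest comparison), so most of that gap, but not all, should be recovered in this assay (a lower number). The expected change is a 4.1-fold lower number from compound 3 to compound 4 (0.61 log units; beyond the scatter) and lies beyond the scatter. For compound 4 the estimate is 21000 nM (expected range 10000 nM to 50000 nM).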

Compound 4, half-maximal inhibitory concentration: 21500 nM
Compound 4: middle estimate off by 1.0-fold (0.01 log units), on the low side; the range from low to high includes it.
By their numbers in this assay, from the lowest: compounds 2 and 4 (each within the scatter of the next); then compound 3. At a limit, above all of these: compound 1.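

In this assay, extending methyl to propyl gives a 4.0-fold lower number from compound 3 to compound 4 (0.60 log units; beyond the scatter), so a clear part of the chain effect is already present at propyl, which the butyl of compound 2 alone could not show. One further carbon then separates nothing: a 2.0-fold higher number from compound 2 to compound 4 (0.30 log units; within the scatter). The step of an at least 4.6-fold lower number from compound 1 to compound 4 (0.66 log units; beyond the scatter) starts from a limit of compound 1, not a number: the limit of > 100000 nM in this assay, at which 1 of the 4 values shown sits.

From the compounds shown here alone, whether a pentyl chain would lower the number further, or the trend has levelled off, stays open. So does whether an amine in place of the chain would keep any of this effect.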